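From hydroxy to methoxy on compound 2

The compounds below may be only part of what the source reports. "The series", "measured", "known", "first", "only" and "open" are said of these compounds alone.

In a functional assay on cells (Melanoma cell, Homo sapiens) for cytotoxicity, with a stated time of 48 h (a higher number here means a weaker inhibitor of growth, a lower number a stronger inhibitor of growth), compound 1 `COc1ccc(CN2C(=O)/C(=C\c3cc(OC)c(OC)c(OC)c3)c3ccccc32)cc1` gives 4500 nM and compound 2 `COc1cc(/C=C2/C(=O)N(C)c3ccc(O)cc32)cc(OC)c1OC` gives 16200 nM as its reading. Compound 2 therefore has the higher number of the two, marking the weaker inhibitor of growth, by a gap beyond the usual scatter. Compound 3 `COc1ccc2c(c1)/C(=C\c1cc(OC)c(OC)c(OC)c1)C(=O)N2C` differs from compound 2 in one place, methyl in place of hydrogen on an oxygen on an aromatic ring in a change from hydroxy to methoxy. Going by the values given here, no measured pair shows this change. Compound 1, without a hydroxy group, sits lower at 4500 nM but differs in more than one place, so it is a weak guide. A modest fall in the number is expected, with the estimated 2.0-fold lower number from compound 2 to compound 3 (0.31 log units; beyond the scatter) in this assay as a rough guide. For compound 3 the estimated value is 8000 nM with a range from 2500 nM to 25000 nM as the expected bounds.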

Compound 3, concentration for total growth inhibition: 21900 nM
Beside the measured number, compound 3's estimate is 2.7-fold (0.44 log units) below it; measured number inside the range.
By their numbers in this assay, from the lowest: compound 1; then compounds 2 and 3 (each within the scatter of the next).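

Changing hydroxy to methoxy at this position gives a 1.4-fold higher number from compound 2 to compound 3 (0.13 log units; within the scatter) in this assay. This single-change pair therefore shows that, on this oxygen on an aromatic ring, methyl can replace hydrogen without moving the reading beyond the usual scatter. No measurement shown here offers an explanation for this result. Still open, on these data alone, is whether a longer chain on that oxygen, or an amine in place of the hydroxy group, would give a reading clearly apart from these. As far as these compounds go, whether the same change behaves alike in other cell types is also open.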